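Replacing a chlorophenyl amide with a morpholine urea

The source may hold more compounds than are shown below. What is called first, only, known or untested is meant among the compounds shown, and "the series" means these compounds.

The series shares one core, seen in compound 1 `CC(C)(C)c1cc(NC(=O)[C@@H]2CCCCN2C2CC2)no1`, where a physicochemical assay for solubility, read by HPLC, at pH 6.8 (on this read-out higher numbers stand for higher solubility and lower numbers for lower solubility), gives compound 1 38 ug/mL. Compound 2 `CC(C)(C)c1cc(NC(=O)[C@@H]2CCCCN2C2CCOCC2)no1` carries oxan-4-yl in place of cyclopropyl and in this assay compound 2 gives 74 ug/mL; the step of a 1.9-fold higher number from compound 1 to compound 2 (0.29 log units; within the scatter) is within the scatter. Compound 3 `CC(C)(C)c1cc(NC(=O)[C@@H]2CCCCN2C(=O)c2ccc(Cl)cc2)no1` stands apart: in this assay compound 3 reaches only the limit < 0.1 ug/mL, which is a limit of the assay and not a number (the limit of < 0.1 ug/mL in this assay, at which 1 of the 3 values shown sits). The steps of an at least 380-fold lower number from compound 1 to compound 3 (2.57 log units; beyond the scatter) and an at least 740-fold lower number from compound 2 to compound 3 (2.86 log units; beyond the scatter) are both large.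

Compound 4 `CC(C)(C)c1cc(NC(=O)[C@@H]2CCCCN2C(=O)N2CCOCC2)no1` keeps the carbonyl on the ring nitrogen of compound 3 but changes what sits on it: morpholin-4-yl in place of 4-chlorophenyl on a carbonyl carbon. Among the compounds with values here, no measured step covers this exact exchange; the two large steps into compound 3 show only how far the (4-chlorophenyl)carbonyl compound lies below the two amines, and the within-scatter step from compound 1 to compound 2 concerns a different place. Since compound 3 sits at a limit, the size of the expected step of an at least 80-fold higher number from compound 3 to compound 4 (1.90 log units; beyond the scatter) is estimated loosely, upward. In this assay compound 4 is expected to give about 8 ug/mL, with a likely range from 1 ug/mL to 50 ug/mL.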

Compound 4, solubility: 45 ug/mL
For compound 4 the middle estimate is 5.6-fold (0.75 log units) below the measured one; measured number inside the range.
By their numbers in this assay, from the lowest: compounds 1, 4 and 2 (each within the scatter of the next). At a limit, below all of these: compound 3.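

In this assay, within the data shown here, morpholin-4-yl in place of 4-chlorophenyl on a carbonyl carbon gives an at least 450-fold higher number from compound 3 to compound 4 (2.65 log units; beyond the scatter), the first reading of a change at this carbonyl with the carbonyl itself kept on the ring nitrogen. The value of compound 3 in that step is a limit of the assay and not a number: the limit of < 0.1 ug/mL in this assay, at which 1 of the 4 values shown sits. The other two steps, a 1.6-fold lower number from compound 2 to compound 4 (0.22 log units; within the scatter) and a 1.2-fold higher number from compound 1 to compound 4 (0.07 log units; within the scatter), are both within the scatter, so among the compounds shown a carbonyl on the ring nitrogen can carry a number that cannot be told apart from those of the two amines, and what separates compound 3 from compound 4 is the group on that carbonyl carbon.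

The compounds shown leave open whether the limit of compound 3 goes with the chlorine or with the aromatic ring, as the two leave together in this exchange, and a plain phenyl or a pyridyl on the carbonyl carbon would bear on that. They also leave open whether the ring oxygen of morpholin-4-yl matters, which piperidin-1-yl or a dimethylamino group in the same place would test.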